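Methoxymethyl in place of 3-chlorophenyl: expected cytotoxicity

The compounds below may be only part of what the source reports. "The series", "measured", "known", "first", "only" and "open" are said of these compounds alone.

Compound 1, `COc1nc2ccccc2cc1/C=C/c1noc(-c2ccc(C)cc2)n1`, in an ADME assay on HepG2 cells (Homo sapiens) for cytotoxicity, read by sulforhodamine B assay, with a stated time of 48 h (on this read-out higher numbers stand for lower toxicity in this test and lower numbers for higher toxicity in this test), gives > 230000 nM, which is a limit of the assay rather than a number.
Compound 2, `COc1nc2ccccc2cc1/C=C/c1noc(-c2cccc(Cl)c2)n1`, in this assay gives > 220000 nM, again a limit of the assay.

Compound 2 therefore stands at a limit: no half-maximal cytotoxic concentration was reached within the tested range. For the measured compounds named here, the only measured step, a step that the two limits leave unreadable from compound 1 to compound 2, cannot be sized, since both ends rest on limits (the limit of > 220000 nM in this assay, at which 1 of the 2 values shown sits, and (the limit of > 230000 nM in this assay, at which 1 of the 2 values shown sits)).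

Compound 3, `COCc1nc(/C=C/c2cc3ccccc3nc2OC)no1`, differs from compound 2 in one place: methoxymethyl in place of 3-chlorophenyl on an aromatic carbon. Going by the values given here, no measured step bears readably on this change. What the data do show is that two different aromatic groups at this position both left the compounds without measurable toxicity in this assay. On that basis compound 3 is expected to remain at the limit as well. The expected step, a step that the limit leaves unreadable from compound 2 to compound 3, is no more than the usual scatter. Compound 3 is thus estimated at 250000 nM in this assay, with a range from 80000 nM to 1000000 nM.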

Compound 3, half-maximal cytotoxic concentration: > 270000 nM
Compound 3: a limit, no number; the forecaster's own chance of this, stated with the estimate: 80%; middle value at least 1.0-fold (0.03 log units) away from the limit.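

Compound 3, like compound 1 and compound 2, rests on a limit of the assay rather than a number, so the steps from compound 1 and from compound 2 to compound 3 cannot be read. The compounds shown leave open whether methoxymethyl, 3-chlorophenyl and 4-methylphenyl differ at all in this assay.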